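The source may hold more compounds than are shown below. What is called first, only, known or untested is meant among the compounds shown, and "the series" means these compounds.

Three compounds from this series were tested in a functional assay on THP-1 cells (Homo sapiens) for inhibition, read by sulforhodamine B assay, with a stated time of 48 h; on this read-out lower numbers stand for stronger inhibition and higher numbers for weaker inhibition. Compound 1, `CCOC(=O)CCO/N=C(/c1ccc(OC)c(OC)c1OC)c1cccc2ccccc12`, gave only the limit of the assay, > 20000 nM, and not a number. Compound 3, `COc1cc(COC(c2ccc(OC)c(OC)c2OC)c2cccc3ccccc23)cc(OC)c1`, likewise returned only the limit, > 20000 nM. Compound 2, `CCOC(=O)C(C)C(O)(c1ccc(OC)c(OC)c1OC)c1cccc2ccccc12`, which is the starting point of the step followed here, also reached only the limit, > 20000 nM. Compound 2 therefore stands at the same place as the two other compounds: all three sit at the limit of > 20000 nM in this assay, at which 3 of the 3 values shown sit, and no difference in potency among them can be read from these results.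

The compound not yet measured is compound 4, `COc1ccc(C(O)(Cc2ccccc2)c2cccc3ccccc23)c(OC)c1OC`. It differs from compound 2 by benzyl in place of 1-(ethoxycarbonyl)ethyl on a saturated chain carbon bound to two aromatic carbons and an oxygen on a saturated carbon. Among the measured compounds shown here, no measured step between two compounds of this set is available, so the size of the change cannot be read from a neighbouring pair; what is known is only that every measured compound, including compound 2, failed to show a numerical half-maximal inhibitory concentration in this assay.

On this basis the step from compound 2 to compound 4 is expected to be none beyond the scatter, that is a step that the limit leaves unreadable from compound 2 to compound 4, and compound 4 is expected to give about 30000 nM in this assay, with a likely range from 8000 nM to 100000 nM, most probably again as a limit rather than a number.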

Compound 4, half-maximal inhibitory concentration: 12400 nM
Compound 4: the middle estimate sits 2.4-fold (0.38 log units) above what was measured, within the range that was stated.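

In this assay, among the compounds shown here, compound 4 gives 12400 nM, the only number among the four values shown, so this position on the saturated chain carbon can carry a group that brings the read-out inside the measurable range. Compound 2 gives > 20000 nM, which is a limit and not a number, and it shares that limit with most of the set: the limit of > 20000 nM in this assay, at which 3 of the 4 values shown sit. Benzyl in place of 1-(ethoxycarbonyl)ethyl therefore gives an at least 1.6-fold lower number from compound 2 to compound 4 (0.20 log units; that floor lies within the scatter), which means that only a floor can be read for this change, and the true gain in this assay could be anything from nothing beyond the scatter to something much larger.

The compounds shown leave open whether the aromatic ring that enters or the ester that leaves matters more, since the one change does both at once. A plain ethyl group, a longer chain ending in a phenyl ring, or a benzyl group carrying an amine or a carboxylic acid at this place would be needed to separate the two and to show how far the number can fall.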